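This account rests on a few compounds, and the source may have more. Where it says the series, first, only, none or still open, it means among the compounds named here.

Measured so far:
compound 1 `COc1cc(OC)c(/C=C/S(=O)(=O)Cc2ccc(F)c(N)c2)c(OC)c1`, 2500 nM
compound 2 `COc1cc(OC)c(/C=C/S(=O)(=O)Cc2ccc(Cl)c(N)c2)c(OC)c1`, 10 nM
compound 3 `COc1cc(OC)c(/C=C/S(=O)(=O)Cc2ccc(OC)c(NC(C(=O)O)c3ccc(F)cc3)c2)c(OC)c1`, 150 nM

In a functional assay on DU-145 cells (Homo sapiens) for cytotoxicity, read by trypan blue exclusion, with a stated time of 96 h (a lower number here means a stronger inhibitor, a higher number a weaker inhibitor), compound 1 gives 2500 nM, while compound 2 gives 10 nM. The change between them, (chloro in place of fluoro on an aromatic carbon), made a large step: a 250-fold lower number from compound 1 to compound 2 (2.40 log units; beyond the scatter). Compound 3 gives 150 nM in this assay; the difference between its core and that of compound 1 is not broken down here.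

Compound 4 `COc1cc(OC)c(/C=C/S(=O)(=O)Cc2ccc(OC)c(NC(C(=O)O)c3ccc(Cl)cc3)c2)c(OC)c1` has not yet been measured. It differs from compound 3 by chloro in place of fluoro on an aromatic carbon. This is the same kind of change as that from compound 1 to compound 2, but not the same: there the exchanged atom stood ortho to an amino group as well as para to a large group, here only para to a large group, on a separate ring. Because the earlier step of a 250-fold lower number from compound 1 to compound 2 (2.40 log units; beyond the scatter) arose at a different place, a smaller step is expected here: a 2.5-fold lower number from compound 3 to compound 4 (0.40 log units; beyond the scatter). The value of compound 4 is estimated at 60 nM, between 15 nM and 250 nM.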

Compound 4, half-maximal inhibitory concentration: 400 nM
Compound 4: the middle estimate sits 6.7-fold (0.82 log units) below what was measured; measured number outside the range, above it.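

In this assay, chloro in place of fluoro on the phenyl ring of the side chain gives a 2.7-fold higher number from compound 3 to compound 4 (0.43 log units; beyond the scatter). Set beside the earlier step, the same exchange behaves differently on the two cores: the same change on two cores in this assay, a 250-fold lower number (2.40 log units; beyond the scatter) from compound 1 to compound 2 and a 2.7-fold higher number (0.43 log units; beyond the scatter) from compound 3 to compound 4, 670-fold (2.82 log units) apart, beyond the scatter of two such steps This shows that, in this series, the result of the exchange on one core does not predict its result on the other, but with only two pairs it does not show why, nor whether the site of the exchange or the rest of the core matters.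

The compounds shown leave open how a bromo group would compare at the same place. They also leave open whether the step would hold with a methyl ester instead of the carboxylic acid.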